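Swapping Bromo for Chloro on Two Related Cores

The compounds below may be only part of what the source reports. "The series", "measured", "known", "first", "only" and "open" are said of these compounds alone.

Compound 1 `NC1=NC2(CCOCC2)N(OCCCOc2ccccc2Cl)C(N)=N1` and compound 2 `NC1=NC2(CCOCC2)N(OCCCOc2ccccc2Br)C(N)=N1` share one core; compound 3 `NC1=NC2(CCSCC2)N(OCCCOc2ccccc2Br)C(N)=N1` and compound 4 `NC1=NC2(CCSCC2)N(OCCCOc2ccccc2Cl)C(N)=N1` share another, and the difference between the two cores is not broken down here. In an assay on isolated protein for inhibition of Dihydrofolate reductase (Homo sapiens), read by spectrophotometry, using NADPH, with stated times of 5 s and 6 min, tested at 50 uM (on this read-out lower numbers stand for a weaker effect and higher numbers for a stronger effect at the one concentration tested), compound 1 gives 88.2%, compound 2 gives 85%, and compound 3 gives 89.6%. The change chloro in place of bromo on an aromatic carbon went with a number 3.2 percentage points higher from compound 2 to compound 1 (within the scatter). Compound 4 carries the same change, (chloro in place of bromo on an aromatic carbon), on the core of compound 3. Resting on compound 3 at 89.6% and on the earlier a number 3.2 percentage points higher from compound 2 to compound 1 (within the scatter), the expected step is a number 1.4 percentage points higher from compound 3 to compound 4 (within the scatter), which stays within the usual scatter. Compound 4 is therefore estimated at 91%, with a likely range from 84% to 97%.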

Compound 4, a percentage reported as inhibition, at one concentration (the size of the read-out at that concentration, not a potency): 89.6%
Compound 4: the middle estimate sits 1.4 percentage points above what was measured; the range from low to high includes it.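

In this assay, chloro in place of bromo on the core of compound 3 gives no change at the digits printed from compound 3 to compound 4 (within the scatter). Set beside the same change on the other core, the two steps do not differ by more than the scatter allows: the same change on two cores in this assay, a number 3.2 percentage points higher (within the scatter) from compound 2 to compound 1 and no change at the digits printed (within the scatter) from compound 3 to compound 4, 3.2 percentage points apart, within the scatter of two such steps. This shows that the change behaves alike on these two cores as far as this read-out can tell, but it does not show that the change has any real effect, since both steps lie within the scatter and each rests on a single tested concentration.

The compounds shown carry only bromo or chloro on the aromatic ring, so it stays open how a methoxy group or a nitrile there would read. Going by these compounds, a longer chain in place of the present one also remains open.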